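The compounds below may be only part of what the source reports. "The series", "measured", "known", "first", "only" and "open" are said of these compounds alone.

In a functional assay on Raji cells (Homo sapiens) for antiproliferative activity, read by CCK-8 assay, with a stated time of 24 h (a lower number here means a stronger inhibitor, a higher number a weaker inhibitor), compound 1 `C=CC(=O)Nc1cccc(Nc2nc(N)nc(Nc3ccc(OCCOC)cc3)n2)c1` gives 18300 nM and compound 2 `C=CC(=O)Nc1cccc(Nc2ncnc(Nc3ccc(C(=O)Nc4ccc(C)cn4)cc3)n2)c1` gives 125000 nM, the higher of the two numbers; the gap between them lies beyond the usual scatter, so compound 2 is the weaker inhibitor of the pair. Compound 3 `C=CC(=O)Nc1cccc(Nc2ncnc(Nc3ccc(-c4ccc(F)nc4)cc3)n2)c1` differs from compound 2 in one place: 6-fluoropyridin-3-yl in place of (5-methylpyridin-2-yl)carbamoyl on an aromatic carbon. Going by the values given here, no measured pair shows this exact change, so the expectation rests on the two values alone. The step from compound 2 to compound 3 in this assay is expected to be modest, toward a lower number, a 2.5-fold lower number from compound 2 to compound 3 (0.40 log units; beyond the scatter). Compound 3 is estimated at 50000 nM, within a range from 10000 nM to 200000 nM.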

Compound 3, half-maximal inhibitory concentration: 3250 nM
Beside the measured number, compound 3's estimate is 15-fold (1.19 log units) above it, outside the stated range (below it).
By their numbers in this assay, from the lowest: compound 3; then compound 1; then compound 2.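

In this assay, the group at this position, on an aromatic carbon para to a large group, strongly affects the result: 6-fluoropyridin-3-yl in place of (5-methylpyridin-2-yl)carbamoyl gives a 38-fold lower number from compound 2 to compound 3 (1.59 log units; beyond the scatter). The change swaps one pyridine-bearing group for another, while the entering group has fewer heavy atoms and no hydrogen-bond donor. No available evidence explains the difference.

This single step cannot separate the contribution of the fluorine from that of losing the carbamoyl link. From the compounds shown here alone, whether a simple phenyl ring, or a pyridine carrying chlorine or an amine instead of fluorine, would give a similar number remains open.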